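This account rests on a few compounds, and the source may have more. Where it says the series, first, only, none or still open, it means among the compounds named here.

Compound 1 `CCC(C(=O)N1CCN(c2cccc(F)c2)CC1)N1C(=O)CCC1=O` stands highest of the two numbers in a functional assay on the whole organism (strain Swiss) with Mus musculus as the target, in the maximal electroshock model, with a stated time of 0.5 h, at a dose of 300 mg/kg by the intraperitoneal route (on this read-out higher numbers stand for a stronger effect at the one dose given and lower numbers for a weaker effect), where compound 1 gives 100%. Going by the values given here, the only other measured compound, compound 2 `CC(C(=O)N1CCN(c2cccc(F)c2)CC1)N1C(=O)CCC1=O`, gives 50% in this assay, and the step of a number 50 percentage points lower from compound 1 to compound 2 (beyond the scatter) concerns hydrogen in place of methyl on a saturated chain carbon. Compound 3 `CCC(C(=O)N1CCN(c2cccc(C)c2)CC1)N1C(=O)CCC1=O` differs from compound 1 by methyl in place of fluoro on an aromatic carbon. Among the compounds with values here, no measured step touches the aromatic ring, so the data give no size or direction for this change, while the chain methyl of compound 1 is kept. Compound 3 is therefore expected to show no change at the digits printed from compound 1 to compound 3 (within the scatter), nothing beyond the scatter. The estimated value of compound 3 in this assay is 100%, between 75% and 100%.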

Compound 3, a percentage reported as activity, at one dose (the size of the read-out at that dose, not a potency): 100%
For compound 3 middle estimate and measured number coincide at the digits printed, within the range that was stated.
By their numbers in this assay, from the lowest: compound 2; then compounds 1 and 3 (each within the scatter of the next).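

In this assay, going by these compounds alone, the swap from 3-fluorophenyl to 3-methylphenyl comes to no change at the digits printed from compound 1 to compound 3 (within the scatter), the first reading at this aromatic carbon, as the earlier step concerned only the saturated chain. With the chain methyl kept, fluoro and methyl on this carbon are thus not told apart at the one dose given. No evidence at hand bears on the reason for this. Open, going by these compounds, is how a chloro or methoxy group, or a plain phenyl, would read at this place. Also open, on these data alone, is whether a longer chain in place of the chain methyl would hold the read-out with either ring.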